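The source may report more compounds than this note shows. Statements on the series, on what has been measured and on what is new or still open speak of the compounds shown alone.

Three members of one urea-bearing series have been examined in a functional assay on KETR3 cells (Homo sapiens) for inhibition, read by MTT assay, with a stated time of 120 h; on this read-out higher numbers stand for weaker inhibition and lower numbers for stronger inhibition. Compound 1 `O=C(/C=C/c1ccc(NC(=O)Nc2ccc(Cl)c(C(F)(F)F)c2)cc1)NC1CCC1` gives 17300 nM in this assay. Compound 2 `CNC(=O)/C=C/c1ccc(NC(=O)Nc2ccc(Cl)c(C(F)(F)F)c2)cc1` gives 21200 nM, and the change between them is a 1.2-fold higher number from compound 1 to compound 2 (0.09 log units; within the scatter). For compound 3 `CNC(=O)/C(C)=C/c1ccc(NC(=O)Nc2ccc(Cl)c(C(F)(F)F)c2)cc1` this assay reports only a limit, > 50000 nM (the limit of > 50000 nM in this assay, at which 1 of the 3 values shown sits). Compound 3 therefore stands at the weak end of the three, since the steps are an at least 2.8-fold higher number from compound 1 to compound 3 (0.46 log units; beyond the scatter) and an at least 2.3-fold higher number from compound 2 to compound 3 (0.37 log units; beyond the scatter).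

Compound 4 `CNC(=O)c1cccc(-c2ccc(NC(=O)Nc3ccc(Cl)c(C(F)(F)F)c3)cc2)c1` differs from compound 3 in one place: 3-(methylcarbamoyl)phenyl in place of 2-(methylcarbamoyl)prop-1-en-1-yl on an aromatic carbon. The measured steps bear on this only in part. The steps of an at least 2.3-fold higher number from compound 2 to compound 3 (0.37 log units; beyond the scatter) and an at least 2.8-fold higher number from compound 1 to compound 3 (0.46 log units; beyond the scatter) concern the methyl on the chain, which compound 4 lacks, and the step of a 1.2-fold higher number from compound 1 to compound 2 (0.09 log units; within the scatter) concerns the amide substituent, which compound 4 keeps. Among the compounds with values here, no measured pair exchanges the chain for a ring. One therefore expects compound 4 to move back toward the numbers of compound 1 and compound 2, a step estimated as an at least 3.3-fold lower number from compound 3 to compound 4 (0.52 log units; beyond the scatter). Compound 4 is estimated at 15000 nM, with a range from 4000 nM to 50000 nM.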

Compound 4, half-maximal inhibitory concentration: 39300 nM
Beside the measured number, compound 4's estimate is 2.6-fold (0.42 log units) below it, and the stated range covers the measured number.
By their numbers in this assay, from the lowest: compounds 1, 2 and 4 (each within the scatter of the next, the first and the last beyond it). At a limit, above all of these: compound 3.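

In this assay, within the data shown here, the aromatic carbon para to a large group carries a ring for the first time, 3-(methylcarbamoyl)phenyl, where the earlier compounds carried only open chains. Set against the unbranched chain with the same methyl amide, this exchange gives a 1.9-fold higher number from compound 2 to compound 4 (0.27 log units; within the scatter), and set against the chain with the cyclobutyl amide it gives a 2.3-fold higher number from compound 1 to compound 4 (0.36 log units; beyond the scatter), so the ring keeps the number close to that of compound 2 and only modestly off that of compound 1. Compound 3 is reported only as a limit, so its step is a floor, an at least 1.2-fold lower number from compound 3 to compound 4 (0.10 log units; that floor lies within the scatter), and the true size of this change cannot be read: the limit of > 50000 nM in this assay, at which 1 of the 4 values shown sits.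

Left open is whether the ring compound would keep its number with cyclobutyl in place of methyl on the amide nitrogen. Also open, on these data alone, is how a carboxylic acid or an amine in place of the methylcarbamoyl group on that ring would read.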